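From Chloro to Cyano on the Biaryl Ring

The compounds below may be only part of what the source reports. "The series", "measured", "known", "first", "only" and "open" are said of these compounds alone.

Going by the values given here, compound 2 `O=C(O)CS(=O)(=O)c1ccc(OCc2cccc(-c3ccccc3Cl)c2)cc1` gives 28.8 nM in a functional assay on CHO cells for agonist activity at Free fatty acid receptor 1 (Homo sapiens), read by FLIPR and calcium flux (a lower number here means that less compound is needed, a higher number that more compound is needed for the effect), the lowest of the two numbers so far, while compound 1 `O=C(O)CS(=O)(=O)c1ccc(OCc2cccc(-c3ccccc3F)c2)cc1` gives 257 nM. Among the compounds with values here, the one measured step, an 8.9-fold lower number from compound 1 to compound 2 (0.95 log units; beyond the scatter), lies beyond the scatter. Compound 3 `N#Cc1ccccc1-c1cccc(COc2ccc(S(=O)(=O)CC(=O)O)cc2)c1` differs from compound 2 by cyano in place of chloro on an aromatic carbon. Within the data shown here, no measured step swaps chloro for cyano; the fluoro-to-chloro step bears on it only loosely. For compound 3 a step of a 1.9-fold higher number from compound 2 to compound 3 (0.28 log units; within the scatter) is expected, toward a somewhat higher number. Compound 3 is therefore estimated at 55 nM, with a range from 15 nM to 200 nM.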

Compound 3, half-maximal effective concentration: 457 nM
Estimate against measurement, compound 3: 8.3-fold (0.92 log units) below; the whole stated range lies below it.
By their numbers in this assay, from the lowest: compound 2; then compounds 1 and 3 (each within the scatter of the next).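

Going by these compounds alone, replacing chloro with cyano on this aromatic carbon costs far more in this assay than the single earlier step could show (a 16-fold higher number from compound 2 to compound 3 (1.20 log units; beyond the scatter)). Cyano and fluoro give no separable result here (a 1.8-fold higher number from compound 1 to compound 3 (0.25 log units; within the scatter)), so among these three groups only chloro gives the low number. Nothing available explains why this position responds in this way.

The compounds shown leave open whether a bromo or methyl group here would match chloro or fall with fluoro and cyano. They also leave open whether a methoxy group would do the same.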